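The source may hold more compounds than are shown below. What is called first, only, known or untested is meant among the compounds shown, and "the series" means these compounds.

Measured in a functional assay on KB cells (Homo sapiens) for cytotoxicity, read by resazurin assay, with a stated time of 3 days; a lower number here means a stronger inhibitor, a higher number a weaker inhibitor:
- compound 1 `CCCC(C)C(=O)NCC(C)(C)CC1=C(O)C(=O)c2ccccc2C1=O`: 47100 nM
- compound 2 `CCCCCC(=O)OCC(C)(C)CC1=C(O)C(=O)c2ccccc2C1=O`: 41000 nM

Compound 2, at 41000 nM, sits within the scatter of compound 1, at 47100 nM, so the two cannot be ranked. Both numbers lie in the same high range, and the series offers no stronger reference point.

The next compound is compound 3 `CCCCCCCC(=O)OCC(C)(C)CC1=C(O)C(=O)c2ccccc2C1=O`. It differs from compound 2 by ethyl in place of hydrogen on a saturated chain carbon, five bonds along the chain from a carbonyl carbon. The same difference, cut further out, reads propyl to pentyl.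

For the measured compounds named here, only one measured step bears on this, and only loosely: a 1.1-fold lower number from compound 1 to compound 2 (0.06 log units; within the scatter). That step replaces ((1-methylbutyl)carbonyl)amino with (pentylcarbonyl)oxy and does not extend a chain. Going by the values given here, no measured pair shows what added chain length does in this assay, so the direction remains open. The small size of that one step gives no reason to expect a large change, and only a slight lean toward a lower number is assumed. The expected change is a 1.3-fold lower number from compound 2 to compound 3 (0.12 log units; within the scatter), which is no step beyond the scatter.

For compound 3 the estimated value is 31000 nM, with an expected range of 12000 nM to 70000 nM.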

Compound 3, half-maximal inhibitory concentration: 38300 nM
Estimate against measurement, compound 3: 1.2-fold (0.09 log units) below; measured number inside the range.
By their numbers in this assay, from the lowest: compounds 3, 2 and 1 (each within the scatter of the next).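

In this assay, ethyl in place of hydrogen on a saturated chain carbon, five bonds along the chain from a carbonyl carbon, gives a 1.1-fold lower number from compound 2 to compound 3 (0.03 log units; within the scatter) and so leaves compound 2 and compound 3 unranked. For the compounds shown here, this is the first measured pair that bears on chain length at this position, and over this one extension, which also reads propyl to pentyl, the number does not move beyond the scatter and remains in the same high range. Nothing on hand offers an explanation for this flat result.

As far as these compounds go, a single pair sets no trend, so whether a longer chain, or a chain ending in an amine or a carboxylic acid, would shift the number beyond the scatter remains open. Also open, from the compounds shown here alone, is whether the same extension would read the same way on a chain carrying the ((1-methylbutyl)carbonyl)amino group in place of the (pentylcarbonyl)oxy group.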